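Bromo to fluoro: a step expected within the scatter

This account rests on a few compounds, and the source may have more. Where it says the series, first, only, none or still open, it means among the compounds named here.

compound 1 `O=C(CN1CCN(C(=O)c2ccc(F)cc2)CC1)N1CCN(CCCc2c[nH]c3ccc(F)cc23)CC1`: 121000 nM
compound 2 `COc1ccc(C(=O)N2CCN(CC(=O)N3CCN(CCCc4c[nH]c5ccc(OC)cc45)CC3)CC2)cc1`: 190000 nM
compound 3 `COc1ccc2[nH]cc(CCCN3CCN(C(=O)CN4CCN(C(=O)c5ccc(Br)cc5)CC4)CC3)c2c1`: 150000 nM

All three numbers come from an ADME assay on SH-SY5Y cells (Homo sapiens) for cytotoxicity, read by MTT assay, with a stated time of 72 h; on this read-out lower numbers stand for stronger inhibition and higher numbers for weaker inhibition. In this assay compound 3 gives 150000 nM, which lies within the usual scatter of both other compounds, so the three cannot be ranked with any confidence.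

Compound 4 `COc1ccc2[nH]cc(CCCN3CCN(C(=O)CN4CCN(C(=O)c5ccc(F)cc5)CC4)CC3)c2c1` has not yet been measured. It differs from compound 3 in a single place, with fluoro in place of bromo on an aromatic carbon, para to a large group (fluoro in place of bromo on an aromatic carbon).

Within the data shown here, no measured step exchanges bromo for fluoro directly. Among the measured compounds shown here, the one measured step that touches this same aromatic carbon is a 1.3-fold lower number from compound 2 to compound 3 (0.10 log units; within the scatter), where bromo took the place of methoxy. That replacement left the number within the scatter. Compound 1 also carries a 4-fluorophenyl group and gives 121000 nM, but it differs from compound 4 elsewhere as well, so it offers only indirect support.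

On this small evidence, the expected change is a 1.1-fold lower number from compound 3 to compound 4 (0.03 log units; within the scatter), with no step beyond the scatter in either direction. The estimate for compound 4 is 140000 nM, with an expected range from 90000 nM to 220000 nM.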

Compound 4, half-maximal inhibitory concentration: > 200000 nM
Compound 4: no number, only a limit; the forecaster's own chance of this, stated with the estimate: 10%; at least 1.4-fold (0.15 log units) between middle value and limit.
By their numbers in this assay, from the lowest: compounds 1, 3 and 2 (each within the scatter of the next). At a limit, above all of these: compound 4.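

In this assay, as far as these compounds go, compound 4 gives no number but only a limit, > 200000 nM, so the real size of this change stays unknown: the limit of > 200000 nM in this assay, at which 1 of the 4 values shown sits. Fluoro is the third group seen on this aromatic carbon, and the readings are an at least 1.3-fold higher number from compound 3 to compound 4 (0.12 log units; that floor lies within the scatter) and an at least 1.0-fold higher number from compound 2 to compound 4 (0.02 log units; that floor lies within the scatter), so neither exchange lowers the number, though these are floors rather than measured steps and how far the number rises cannot be told. Where the 4-fluorophenyl group stays the same and methoxy takes the place of fluoro on another aromatic carbon of the shared core, the reading is an at least 1.6-fold higher number from compound 1 to compound 4 (0.21 log units; that floor lies within the scatter), again only a floor.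

Every step shown so far, floors included, lies within the scatter, so it remains open whether any group on this carbon can move the number beyond it, and the true value of compound 4 stays unknown. From the compounds shown here alone, what an amine or a carboxylic acid on this carbon would do in this assay also remains open.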